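The compounds below may be only part of what the source reports. "The series", "measured", "known", "first", "only" and "open" are said of these compounds alone.

In a functional assay on SW480 cells (Homo sapiens) for cytotoxicity, read by MTT assay, with a stated time of 48 h (a higher number here means a weaker inhibitor, a lower number a stronger inhibitor), compound 2 `O=c1ccoc2cc(OCc3cn(Cc4ccc(Cl)cc4Cl)nn3)ccc12` reaches only the limit of > 100000 nM. Compound 1 `O=c1ccoc2cc(OCc3cn(Cc4cccc(F)c4)nn3)ccc12` likewise gives only the limit of > 100000 nM. Compound 3 `C#CCOc1ccc2c(=O)ccoc2c1` also gives only the limit of > 100000 nM. All three measured values sit at the same limit (the limit of > 100000 nM in this assay, at which 3 of the 3 values shown sit), so the step that the two limits leave unreadable from compound 1 to compound 2 cannot be read in size or direction. Compound 4 `O=c1ccoc2cc(OCc3cn(Cc4ccc(Br)cc4)nn3)ccc12` carries the following change: 4-bromophenyl in place of 2,4-dichlorophenyl on a saturated chain carbon bound to an aromatic nitrogen. For the measured compounds named here, because every measured compound rests at the limit (the limit of > 100000 nM in this assay, at which 3 of the 3 values shown sit), no measured step points to a gain or loss for compound 4, and no movement beyond the scatter is expected. The step of a number no higher from compound 2 to compound 4 (the limit leaves the size open) is therefore expected to be negligible. Compound 4 is expected to give 100000 nM, between 30000 nM and 300000 nM, most likely reported again as a limit.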

Compound 4, half-maximal inhibitory concentration: 37500 nM
Beside the measured number, compound 4's estimate is 2.7-fold (0.43 log units) above it; the range from low to high includes it.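

In this assay, this position can move the result: the change to 4-bromophenyl gives an at least 2.6-fold lower number from compound 2 to compound 4 (0.42 log units; beyond the scatter), and compared with 3-fluorophenyl it gives an at least 2.6-fold lower number from compound 1 to compound 4 (0.42 log units; beyond the scatter). Both sizes are minimums, as compound 4 alone has a readable number, while the other compounds stay at a limit: the limit of > 100000 nM in this assay, at which 3 of the 4 values shown sit. The step between compound 1 and compound 2 remains unreadable.

From the compounds shown here alone, it remains open whether bromine itself matters or whether 4-chlorophenyl would serve equally. How an amine on this ring or a longer chain would behave is also unknown.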